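Methoxy for methyl on the ketone-side ring

This account rests on a few compounds, and the source may have more. Where it says the series, first, only, none or still open, it means among the compounds named here.

Compound 3 `Cc1ccc(C(=O)/C=C/c2ccc(/C=N/NC(=N)N)cc2)cc1` gives 77.7% in a functional assay on the whole organism (Ear) for inhibition, with Mus musculus as the target, with a stated time of 30 min, at a dose of 100 mg/kg by the intraperitoneal route (a lower number here means less inhibition, a higher number more inhibition at the dose given (going by the name of the read-out)), the highest of the three numbers to hand. For the measured compounds named here, compound 2 `Cc1ccc(C(=O)/C=C/c2ccc(/C=N/NC(=O)c3ccncc3)cc2)c(C)c1` gives 58.5% and compound 1 `Cc1ccc(C(=O)/C=C/c2ccc(/C=N/NC(=O)c3ccccc3)cc2)c(C)c1` gives 0.18%; the one single-place step among them, a number 58.3 percentage points higher from compound 1 to compound 2 (beyond the scatter), concerns the hydrazide end and not the ring changed here. Compound 4 `COc1ccc(C(=O)/C=C/c2ccc(/C=N/NC(=N)N)cc2)cc1` differs from compound 3 by methoxy in place of methyl on an aromatic carbon, on the aromatic carbon that sits para to a large group. Going by the values given here, no measured step touches this ring, so nothing beyond the scatter is expected; the estimated step is a number 3.7 percentage points lower from compound 3 to compound 4 (within the scatter). Compound 4 is therefore expected to give about 74%, within 52% to 92%.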

Compound 4, a percentage reported as inhibition, in the whole organism at one dose (the size of the read-out at that dose, not a potency): 57.2%
Beside the measured number, compound 4's estimate is 16.8 percentage points above it; the measured number falls inside the stated range.
By their numbers in this assay, from the lowest: compound 1; then compounds 4 and 2 (each within the scatter of the next); then compound 3.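

On the aromatic carbon para to a large group, the exchange is not neutral in this assay: methoxy in place of methyl gives a number 20.5 percentage points lower from compound 3 to compound 4 (beyond the scatter). For the compounds shown here, this is the first measured step on this ring, and it shows that the ring's substituent can shift the read-out beyond the scatter, whereas the earlier step concerned only the hydrazide end. Nothing at hand explains the fall.

On these data alone, it remains open whether a chlorine, an ethyl or a hydroxyl at this position would stay nearer compound 3 or compound 4. Also open, as far as these compounds go, is whether the same exchange moves the number similarly with the pyridin-4-yl hydrazide end of compound 2.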